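The source may hold more compounds than are shown below. What is called first, only, known or untested is meant among the compounds shown, and "the series" means these compounds.

Compound 3 `COc1ncc(-c2nc(C(F)(F)F)sc2N2CCN(C(=O)Cn3nc(C)nc3C)[C@H](C)C2)cn1` stands highest of the three numbers in a functional assay on U2OS cells for antagonist activity at C-X-C chemokine receptor type 3 (Homo sapiens), read by beta-arrestin recruitment; a lower number here means a stronger inhibitor, a higher number a weaker inhibitor: compound 3 gives 558 nM, whereas compound 2 `CCOc1ncc(-c2nc(C(F)(F)F)sc2N2CCN(C(=O)Cn3c(=O)oc4ccccc43)[C@H](C)C2)cn1` gives 99 nM and compound 1 `CCOc1ncc(-c2nc(C(F)(F)F)sc2N2CCN(C(=O)Cn3cnc4cccnc43)[C@H](C)C2)cn1` gives 20 nM. Going by the values given here, the only step between two compounds that differ in one place, a 5.0-fold higher number from compound 1 to compound 2 (0.69 log units; beyond the scatter), concerns the group on the saturated chain carbon bound to the carbonyl carbon, not the pyrimidine substituent. Compound 4 `Cc1nc(C)n(CC(=O)N2CCN(c3sc(C(F)(F)F)nc3-c3cnc(N4CCCC4)nc3)C[C@H]2C)n1` differs from compound 3 by pyrrolidin-1-yl in place of methoxy on an aromatic carbon. Among the compounds with values here, no measured step touches that position, so nothing beyond the usual scatter can be predicted with confidence in this assay, and the expectation is a modest change of uncertain direction. Compound 4 is therefore estimated at 400 nM, within a range from 100 nM to 1600 nM. This corresponds to an expected 1.4-fold lower number from compound 3 to compound 4 (0.14 log units; within the scatter).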

Compound 4, half-maximal inhibitory concentration: 523 nM
Beside the measured number, compound 4's estimate is 1.3-fold (0.12 log units) below it, within the range that was stated.
By their numbers in this assay, from the lowest: compound 1; then compound 2; then compounds 4 and 3 (each within the scatter of the next).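

In this assay, going by these compounds alone, pyrrolidin-1-yl in place of methoxy gives a 1.1-fold lower number from compound 3 to compound 4 (0.03 log units; within the scatter), the first measured step at this position. On the aromatic carbon between two ring nitrogen atoms, pyrrolidin-1-yl with its ring thus gives a number that cannot be told apart from that of methoxy without a ring. No supporting evidence bears on this result. Still open, going by these compounds, is how an acyclic amine such as dimethylamino would read at this carbon. Also open, on these data alone, is whether pyrrolidin-1-yl would give a similar result on the compound 1 scaffold.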